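A few compounds are considered here, and "the series" means these few. Any claim that something is new, unique, unknown or untested is made for them only; others in the source may bear on it.

Measured so far in a functional assay on K562 cells (Homo sapiens) for antiproliferative activity, with a stated time of 72 h; on this read-out lower numbers stand for stronger inhibition and higher numbers for weaker inhibition:
- compound 1 `OC[C@H]1O[C@@H](n2cnc3c(NCc4ccccc4Br)ncnc32)[C@H](O)[C@@H]1O`: 10000 nM
- compound 2 `COc1ccccc1CNc1ncnc2c1ncn2[C@@H]1O[C@H](CO)[C@@H](O)[C@H]1O`: 89000 nM
- compound 3 `COc1ccc(CNc2ncnc3c2ncn3[C@@H]2O[C@H](CO)[C@@H](O)[C@H]2O)c(OC)c1`: a limit of the assay, > 166000 nM

Among the two numbers that are not limits, compound 2 stands highest; its nearest neighbour is compound 1, and the step of an 8.9-fold higher number from compound 1 to compound 2 (0.95 log units; beyond the scatter) separates them. On these data alone, compound 3 gives only a limit, (the limit of > 166000 nM in this assay, at which 1 of the 3 values shown sits), so the step of an at least 1.8-fold higher number from compound 2 to compound 3 (0.27 log units; that floor lies within the scatter) has a floor that lies within the scatter, and its true size is unknown.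

Compound 4 `COc1cccc(CNc2ncnc3c2ncn3[C@@H]2O[C@H](CO)[C@@H](O)[C@H]2O)c1O` has not yet been measured. It differs from compound 2 in one place: 2-hydroxy-3-methoxyphenyl in place of 2-methoxyphenyl on a saturated chain carbon bound to a nitrogen on an aromatic ring.

Going by the values given here, two measured steps bear on this change. The step of an 8.9-fold higher number from compound 1 to compound 2 (0.95 log units; beyond the scatter) shows that exchanging the group on that saturated chain carbon moved the number markedly upward, and the step of an at least 1.8-fold higher number from compound 2 to compound 3 (0.27 log units; that floor lies within the scatter) shows that a further substituent on the ring did not lower it, with the result reaching the assay limit. Against that background a rise beyond the scatter is expected for compound 4, possibly again to the limit. Compound 4 is therefore estimated at 150000 nM, with a range from 60000 nM to 400000 nM. The expected step is a 1.7-fold higher number from compound 2 to compound 4 (0.23 log units; within the scatter).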

Compound 4, half-maximal inhibitory concentration: 27900 nM
The estimate for compound 4 lay 5.4-fold (0.73 log units) above the measured number; the whole stated range lies above it.
By their numbers in this assay, from the lowest: compound 1; then compound 4; then compound 2. At a limit, above all of these: compound 3.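

In this assay, going by these compounds alone, the earlier compounds showed the number only rising on moving away from 2-bromophenyl, but here the direction turns: a 3.2-fold lower number from compound 2 to compound 4 (0.50 log units; beyond the scatter) marks 2-hydroxy-3-methoxyphenyl on the saturated chain carbon bound to a nitrogen on an aromatic ring as better than 2-methoxyphenyl, so a larger group at this place need not raise the number. The change does not reach the bromo compound, as a 2.8-fold higher number from compound 1 to compound 4 (0.45 log units; beyond the scatter) remains, and compound 1 keeps the lowest number of the four. The step of an at least 5.9-fold lower number from compound 3 to compound 4 (0.77 log units; beyond the scatter) also lies beyond the scatter, but only its floor is known, and compound 3 counts solely as a limit of the assay: the limit of > 166000 nM in this assay, at which 1 of the 4 values shown sits.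

The compounds shown do not separate the share of the hydroxy group from that of the methoxy group within 2-hydroxy-3-methoxyphenyl, and they give no reason for the step. On these data alone, it also stays open whether an amine or a carboxylic acid on the phenyl ring, or a longer chain leading to that ring, would bring the number nearer to that of compound 1 or beyond it.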